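The compounds below may be only part of what the source reports. "The series", "measured", "known", "first", "only" and "open" are said of these compounds alone.

Working notes on the series. Among the measured compounds shown here, compound 1 `COc1ccc(-c2[nH]c3ccccc3c2/C=C(\C#N)S(=O)(=O)c2ccccc2)cc1` stands at the lowest of the two numbers so far in a functional assay on PC-3 cells (Homo sapiens) for inhibition, read by sulforhodamine B assay, with a stated time of 48 h (on this read-out lower numbers stand for stronger inhibition of growth and higher numbers for weaker inhibition of growth), where compound 1 gives 557 nM. The other measured member, compound 2 `CCOC(=O)C(=Cc1c(-c2ccccc2)[nH]c2ccccc12)C(=O)OCC`, gives 3300 nM in this assay; the two values lie apart beyond the scatter, with compound 1 at the lower number. The two structures differ in more than one place, so no single step can be read between them.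

Compound 3 `COc1ccc(-c2[nH]c3ccc(OC)cc3c2/C=C(\C#N)S(=O)(=O)c2ccccc2)cc1` has not yet been measured in this assay. It differs from compound 1 by one change only, (methoxy in place of hydrogen on an aromatic carbon), a methoxy in place of hydrogen on an aromatic carbon. For the measured compounds named here, no measured step covers this change, so nothing beyond the scatter is expected in this assay, in either direction. For compound 3 the estimated value is 450 nM, within a range of 150 nM to 1300 nM. The expected step is a 1.2-fold lower number from compound 1 to compound 3 (0.09 log units; within the scatter).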

Compound 3, concentration for 50% growth inhibition: 534 nM
Estimate against measurement, compound 3: 1.2-fold (0.07 log units) below; the range from low to high includes it.
By their numbers in this assay, from the lowest: compounds 3 and 1 (each within the scatter of the next); then compound 2.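

Among the compounds shown here, the step of a 1.0-fold lower number from compound 1 to compound 3 (0.02 log units; within the scatter) in this assay is the first that can be read, and it places compound 3 level with compound 1. On an aromatic carbon of the fused system, meta to a fused ring and para to a fused ring, the core of compound 1 therefore carries a methoxy in place of hydrogen with no difference beyond the scatter. No measurement shown gives a reason for this result.

Going by these compounds, whether an amine, a carboxylic acid or a longer chain at this same position would also stay within the scatter remains open. On these data alone, the steps separating compound 2 from compound 1 cannot be read, so the other places in the structure also remain open.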